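The compounds below may be only part of what the source reports. "The series", "measured", "known", "first", "only" and "open" are said of these compounds alone.

Measured so far in an assay on HEK293 cells for inhibition of sodium-dependent dopamine transporter (Homo sapiens), read by scintillation counting, with stated times of 5 min and 1 min; on this read-out higher numbers stand for weaker inhibition and lower numbers for stronger inhibition:
compound 1 `Cc1nc(O)cc(C[S+]([O-])C(c2ccccc2)c2ccccc2)n1` gives 3100 nM
compound 2 `Cc1noc(C[S+]([O-])C(c2ccccc2)c2ccccc2)n1` gives 56700 nM
compound 3 `Cc1cnc(C[S+]([O-])C(c2ccccc2)c2ccccc2)nc1` gives 156000 nM

Compound 3 stands at the highest number of the three, weakest on this read-out; compound 2 lies nearest and compound 1 furthest. Compound 4 `Cc1scc(C[S+]([O-])C(c2ccccc2)c2ccccc2)c1C` is not yet measured. Its change from compound 3 is 4,5-dimethylthiophen-3-yl in place of 5-methylpyrimidin-2-yl on a saturated chain carbon bound to a sulfur. Every measured step also swaps the group at this place, and all were beyond the scatter: an 18-fold higher number from compound 1 to compound 2 (1.26 log units; beyond the scatter), a 50-fold higher number from compound 1 to compound 3 (1.70 log units; beyond the scatter), a 2.8-fold higher number from compound 2 to compound 3 (0.44 log units; beyond the scatter). Among the measured compounds shown here, this spot therefore moves the number a lot, but none of the measured groups resembles the one entering, so the direction is uncertain. Because compound 3 gives 156000 nM, the highest number, a downward step seems more likely than a further rise. Compound 4 is estimated at 30000 nM, range 5000 nM to 200000 nM, a step of a 5.2-fold lower number from compound 3 to compound 4 (0.72 log units; beyond the scatter).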

Compound 4, half-maximal inhibitory concentration: 284000 nM
Estimate against measurement, compound 4: 9.5-fold (0.98 log units) below; the whole stated range lies below it.
By their numbers in this assay, from the lowest: compound 1; then compound 2; then compounds 3 and 4 (each within the scatter of the next).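

In this assay the swap to 4,5-dimethylthiophen-3-yl gives a 1.8-fold higher number from compound 3 to compound 4 (0.26 log units; within the scatter) so this five-membered ring with one hetero atom cannot be told apart from 5-methylpyrimidin-2-yl, a six-membered ring with two. The same group gives a 5.0-fold higher number from compound 2 to compound 4 (0.70 log units; beyond the scatter) and a 92-fold higher number from compound 1 to compound 4 (1.96 log units; beyond the scatter) so compound 1, with 6-hydroxy-2-methylpyrimidin-4-yl, keeps the lowest number by a wide margin. Nothing measured here explains these differences.

The compounds shown leave open whether the hydroxy group of compound 1 matters in itself, and how an amino group in its place would read.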